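Swapping Bromo for Nitro: Expectations for Compound 3

The compounds below may be only part of what the source reports. "The series", "measured", "known", "first", "only" and "open" are said of these compounds alone.

In a functional assay on the whole organism (strain Albino Wistar) for inhibition, with Rattus norvegicus as the target, read by paw edema, with stated times of 1 h and 3 h, at a dose of 10 mg/kg by the oral route (on this read-out higher numbers stand for more inhibition at the one dose given (going by the name of the read-out) and lower numbers for less inhibition), compound 1 `Fc1ccc(-n2cc(CSc3nc4ccccc4s3)nn2)cc1` gives 77.8%, and compound 2 `Brc1ccc(-n2cc(CSc3nc4ccccc4s3)nn2)cc1` gives 75%. Within the data shown here, the only measured step, a number 2.8 percentage points lower from compound 1 to compound 2 (within the scatter), lies within the scatter, so the two numbers cannot be ranked; compound 2 simply carries the smaller of the two figures, with compound 1 its nearest and only neighbour.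

Compound 3 `O=[N+]([O-])c1ccc(-n2cc(CSc3nc4ccccc4s3)nn2)cc1` differs from compound 2 by nitro in place of bromo on an aromatic carbon. Among the measured compounds shown here, the single measured step bears on this change only loosely: it exchanged one halogen for another on the same aromatic carbon and moved the read-out by a number 2.8 percentage points lower from compound 1 to compound 2 (within the scatter), within the scatter. For the measured compounds named here, no measured step shows a nitro group entering, so the data give no direction for this change. Compound 3 is therefore expected to stay close to compound 2, with an estimated step of no change at the digits printed from compound 2 to compound 3 (within the scatter). The estimate for compound 3 is 75%, ranging from 60% to 88%.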

Compound 3, a percentage reported as inhibition, in the whole organism at one dose (the size of the read-out at that dose, not a potency): 75%
Compound 3: the middle estimate sits on the measured number at the digits printed; the measured number falls inside the stated range.
By their numbers in this assay, from the lowest: compounds 2, 3 and 1 (each within the scatter of the next).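

In this assay nitro in place of bromo gives no change at the digits printed from compound 2 to compound 3 (within the scatter) and nitro in place of fluoro gives a number 2.8 percentage points lower from compound 1 to compound 3 (within the scatter) at this same place, an aromatic carbon para to a large group. The earlier compounds shown here carried only halogens here, whereas compound 3 shows that a group that is no halogen, and that brings hydrogen-bond acceptors, can stand at this place with no step beyond the scatter, so the three numbers cannot be ranked. No measured evidence is at hand to say what lies behind this result.

Going by these compounds, whether an amine, a carboxylic acid or a methyl group at this place would stay within the scatter of these numbers remains open. On these data alone, with one dose, it also remains open whether these three compounds differ in potency.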